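A few compounds are considered here, and "the series" means these few. Any claim that something is new, unique, unknown or untested is made for them only; others in the source may bear on it.

Measured so far in an ADME assay on HeLa cells (Homo sapiens) for cytotoxicity, read by sulforhodamine B assay, with a stated time of 48 h, tested at 10 uM; a higher number here means more inhibition at the concentration tested (going by the name of the read-out), a lower number less inhibition:

Compound 1 `CCCCCCCc1cn(C(c2ccccc2)c2cc3cc(Br)ccc3nc2OC)nn1`: compound 1 gives 9.7%.
Compound 2 `CCCCCCCCc1cn(C(c2ccccc2)c2cc3cc(Br)ccc3nc2OC)nn1`: compound 2 gives 0.1%.

Among the compounds with values here, compound 2 holds the lower of the two numbers, and its only neighbour is compound 1; the step of a number 9.6 percentage points lower from compound 1 to compound 2 (within the scatter) lies within the scatter, so the two compounds are indistinguishable on this read-out. Compound 3 `COc1nc2ccc(Br)cc2cc1C(c1ccccc1)n1cc(-c2ccc(OC(F)(F)F)cc2)nn1` is the next compound, and it differs from compound 2 in one place: 4-(trifluoromethoxy)phenyl in place of octyl on an aromatic carbon. Within the data shown here, the single measured step concerns a chain one carbon longer and says nothing about replacing the whole chain with an aromatic group, so nothing measured bears directly on this change. Among the measured compounds shown here, with the two known numbers both low, the expectation for compound 3 is a step of a number 7.9 percentage points higher from compound 2 to compound 3 (within the scatter) that stays within the scatter, though with a wide range of uncertainty. Compound 3 is therefore estimated at 8%, between 0% and 30%.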

Compound 3, a percentage reported as inhibition, at one concentration (the size of the read-out at that concentration, not a potency): -2.24%
Compound 3: middle estimate off by 10.2 percentage points, on the high side; measured number outside the range, below it.
By their numbers in this assay, from the lowest: compounds 3, 2 and 1 (each within the scatter of the next, the first and the last beyond it).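

On the aromatic carbon of the five-membered ring with 3 nitrogen, an aromatic group can now be set against the saturated chains. In this assay, 4-(trifluoromethoxy)phenyl in place of octyl gives a number 2.3 percentage points lower from compound 2 to compound 3 (within the scatter), so these two compounds cannot be told apart, while the same group in place of heptyl gives a number 11.9 percentage points lower from compound 1 to compound 3 (beyond the scatter), a modest step and the only one so far beyond the scatter. This carbon can therefore carry a ring as well as a chain with no gain in inhibition at the concentration tested, and nothing measured here accounts for either step.

As far as these compounds go, whether an amine, a carboxylic acid or a much shorter chain such as ethyl at this carbon would raise the inhibition remains open. Also open, from the compounds shown here alone, is whether plain phenyl would match compound 3.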